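The source may hold more compounds than are shown below. What is called first, only, known or untested is meant among the compounds shown, and "the series" means these compounds.

Measured so far:
Compound 1 `Cc1noc(C)c1-c1cnc(N)c(Oc2ccc(C(=O)Nc3ccccc3)cc2)n1` gives 26600 nM in a functional assay on U-87MG ATCC cells for inhibition, with U-87 MG (Homo sapiens) as the target, read by MTT assay, with a stated time of 72 h; on this read-out higher numbers stand for weaker inhibition and lower numbers for stronger inhibition.
Compound 2 `Cc1noc(C)c1-c1cnc(N)c(Oc2ccc(C(=O)Nc3ccc(Cl)cn3)cc2)n1` gives 45600 nM in this assay.
Compound 3 `Cn1cc(-c2cnc(N)c(Oc3ccc(C(=O)Nc4ccccc4)cc3)n2)cn1` gives 17700 nM in this assay.

Compound 3 carries the lowest of the three numbers, but its gap to compound 1 lies within the scatter; only its gap to compound 2 lies beyond it. Compound 4 `Cn1cc(-c2cnc(N)c(Oc3ccc(C(=O)Nc4cccc(Cl)n4)cc3)n2)cn1` arises from compound 3 by 6-chloropyridin-2-yl in place of phenyl on an amide-type nitrogen. For the measured compounds named here, one measured step bears on this change: a 1.7-fold higher number from compound 1 to compound 2 (0.23 log units; within the scatter), where another chloropyridin-2-yl group replaced phenyl on the same amide-type nitrogen, though in the other core. That the core matters little here is suggested by a 1.5-fold lower number from compound 1 to compound 3 (0.18 log units; within the scatter). Both steps stayed within the scatter, so no step beyond the scatter is expected in this assay for compound 4, with at most a slight drift toward a higher number. Compound 4 is therefore expected at 25000 nM, with a range from 10000 nM to 65000 nM. This estimate means an expected 1.4-fold higher number from compound 3 to compound 4 (0.15 log units; within the scatter).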

Compound 4, half-maximal inhibitory concentration: 54800 nM
Estimate against measurement, compound 4: 2.2-fold (0.34 log units) below; measured number inside the range.
By their numbers in this assay, from the lowest: compounds 3, 1, 2 and 4 (each within the scatter of the next, the first and the last beyond it).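

For the compounds shown here, replacing phenyl on the amide-type nitrogen with 6-chloropyridin-2-yl gives a 3.1-fold higher number from compound 3 to compound 4 (0.49 log units; beyond the scatter) in this assay, the first single-place change to go beyond the scatter. The earlier exchange at this nitrogen, 5-chloropyridin-2-yl for phenyl, gave a 1.7-fold higher number from compound 1 to compound 2 (0.23 log units; within the scatter), which points the same way, but only the new step can be told from the scatter. Nothing available explains why this change weakens inhibition in these cells.

The two steps differ both in the chlorine-bearing group and in the group on the shared core, so the compounds shown leave open which of these sets their size apart. Also open, as far as these compounds go, is how pyridin-2-yl without chlorine would read on this nitrogen, or a pyridin-2-yl carrying an amine or a methoxy group in place of the chlorine.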